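The compounds below may be only part of what the source reports. "The series", "measured", "known", "first", "only" and "open" are said of these compounds alone.

Values in an ADME assay on cells (Hepatocyte, Homo sapiens) for metabolic stability; a lower number here means that the compound disappears faster, a higher number that the compound lasts longer:
- Compound 1 `O=C(OC1CCC(CN2CCN(c3cc(=O)c4cc(C(F)(F)F)cc([N+](=O)[O-])c4s3)CC2)CC1)c1ccccc1`: 0.603 h.
- Compound 2 `O=C(OC1CCC(CN2CCN(c3cc(=O)c4cc(C(F)(F)F)cc([N+](=O)[O-])c4s3)CC2)CC1)c1ccncc1`: 0.075 h.
- Compound 3 `CC(=O)OC1CCC(CN2CCN(c3cc(=O)c4cc(C(F)(F)F)cc([N+](=O)[O-])c4s3)CC2)CC1`: < 0.15 h, a limit.

Compound 3 has only this limit and no exact number, so it gives an uncertain starting point. Compound 4 `O=C(OC1CCC(CN2CCN(c3cc(=O)c4cc(C(F)(F)F)cc([N+](=O)[O-])c4s3)CC2)CC1)c1ccco1` has furan-2-yl in place of methyl on a carbonyl carbon. The closest guides are changes at the same carbonyl carbon. Replacing phenyl with methyl gave an at least 4.0-fold lower number from compound 1 to compound 3 (0.60 log units; beyond the scatter), and replacing phenyl with pyridin-4-yl gave an 8.0-fold lower number from compound 1 to compound 2 (0.91 log units; beyond the scatter). The remaining comparison, a step that the limit leaves unreadable from compound 2 to compound 3, gives no size. Compound 4 keeps an aromatic ring, but the two ring-bearing compounds differ widely, as an 8.0-fold lower number from compound 1 to compound 2 (0.91 log units; beyond the scatter) shows, so only a modest rise is expected. The expected step is an at least 1.3-fold higher number from compound 3 to compound 4 (0.12 log units; that floor lies within the scatter). For compound 4, the estimated half-life is 0.2 h, with an expected range from 0.07 h to 0.6 h.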

Compound 4, half-life: 0.075 h
For compound 4 the middle estimate is 2.7-fold (0.43 log units) above the measured one; measured number inside the range.
By their numbers in this assay, from the lowest: compounds 2 and 4 (each within the scatter of the next); then compound 1.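

Replacing pyridin-4-yl with furan-2-yl on the carbonyl carbon gives no change at the digits printed from compound 2 to compound 4 (within the scatter) in this assay, while replacing phenyl with furan-2-yl gives an 8.0-fold lower number from compound 1 to compound 4 (0.91 log units; beyond the scatter). At this position, then, keeping an aromatic ring is not enough to keep the longer half-life: of the three rings shown, only phenyl stands apart. Steps involving compound 3 cannot be read, since its value is only a limit: the limit of < 0.15 h in this assay, at which 1 of the 4 values shown sits.

On these data alone, whether a cyclohexyl group or a longer chain on this carbonyl carbon would match phenyl stays open.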